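The source may hold more compounds than are shown below. What is called first, only, known or untested is meant among the compounds shown, and "the series" means these compounds.

In a functional assay on MCF7 cells (Homo sapiens) for antiproliferative activity, read by MTT assay, with a stated time of 48 h (on this read-out higher numbers stand for weaker inhibition and lower numbers for stronger inhibition), compound 1 `COc1ccc(C2OC(c3ccc4ccccc4c3)=NN2C(C)=O)cc1` gives 7.35 ug/mL, compound 2 `CC(=O)N1N=C(c2ccc3ccccc3c2)OC1c1cccc(Br)c1` gives 2.34 ug/mL and compound 3 `CC(=O)N1N=C(c2ccc3ccccc3c2)OC1c1ccc(F)cc1` gives 3.02 ug/mL. Compound 3 therefore sits within the scatter of compound 2, and both lie clearly lower than compound 1.

Compound 4 `CC(=O)N1N=C(c2ccc3ccccc3c2)OC1c1ccc([N+](=O)[O-])cc1` differs from compound 3 as follows: nitro in place of fluoro on an aromatic carbon. In short, nitro in place of fluoro on an aromatic carbon.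

Within the data shown here, no measured step involves nitro. The closest evidence is a 2.4-fold lower number from compound 1 to compound 3 (0.39 log units; beyond the scatter), a modest step, and a 1.3-fold higher number from compound 2 to compound 3 (0.11 log units; within the scatter), which stays within the scatter. Neither fixes a direction, so no shift beyond the scatter is firmly expected in this assay. The estimated change is a 1.2-fold higher number from compound 3 to compound 4 (0.06 log units; within the scatter). Compound 4 is estimated at 3.5 ug/mL, with an expected range of 1.4 ug/mL to 8.5 ug/mL.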

Compound 4, half-maximal inhibitory concentration: 7.59 ug/mL
Compound 4: the middle estimate sits 2.2-fold (0.34 log units) below what was measured, and the stated range covers the measured number.
By their numbers in this assay, from the lowest: compounds 2 and 3 (each within the scatter of the next); then compounds 1 and 4 (each within the scatter of the next).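

In this assay, the aromatic carbon para to a large group does not tolerate every group alike: nitro in place of fluoro gives (a 2.5-fold higher number from compound 3 to compound 4 (0.40 log units; beyond the scatter)), and 4-nitrophenyl in place of 3-bromophenyl gives (a 3.2-fold higher number from compound 2 to compound 4 (0.51 log units; beyond the scatter)). Nitro in place of methoxy gives (a 1.0-fold higher number from compound 1 to compound 4 (0.01 log units; within the scatter)), so compounds with these two different groups stand level, and both lie above the fluoro compound 3. Nothing available accounts for these steps. As far as these compounds go, whether an amine or a carboxylic acid at this position would stand with fluoro or with nitro and methoxy remains open.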